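Opening the Ring: An Estimate for Compound 4

This account rests on a few compounds, and the source may have more. Where it says the series, first, only, none or still open, it means among the compounds named here.

Compound 1 `CCN1CCCC[C@H]1[C@H]1COC(c2ccccc2)(c2ccccc2)O1` gives 6900 nM in a functional assay (brain) for displacement of a labelled ligand, with Rattus norvegicus as the target (a lower number here means a stronger inhibitor, a higher number a weaker inhibitor), the lowest of the three numbers recorded. Compound 2 `CCCCCCN1CCCC[C@H]1[C@H]1COC(c2ccccc2)(c2ccccc2)O1` gives 21200 nM and compound 3 `C=CCN1CCCC[C@H]1[C@H]1COC(c2ccccc2)(c2ccccc2)O1` gives 15200 nM; the steps of a 3.1-fold higher number from compound 1 to compound 2 (0.49 log units; beyond the scatter) and a 2.2-fold higher number from compound 1 to compound 3 (0.34 log units; beyond the scatter) are both modest yet beyond the scatter, while a 1.4-fold lower number from compound 2 to compound 3 (0.14 log units; within the scatter) stays within it. Compound 4 `CCC[C@H](N)[C@H]1COC(c2ccccc2)(c2ccccc2)O1` carries the change (1-aminobutyl in place of 1-ethylpiperidin-2-yl on a saturated ring carbon). Going by the values given here, no measured step touches this part of the structure; the two steps that alter the group on the ring nitrogen each gave a modestly higher number, so compound 1 appears to sit near the best of this small set. Compound 4 is therefore expected to show a 2.2-fold higher number from compound 1 to compound 4 (0.34 log units; beyond the scatter). The estimated value for compound 4 is 15000 nM, within 4000 nM to 60000 nM.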

Compound 4, inhibition constant: 3450 nM
The estimate for compound 4 lay 4.3-fold (0.64 log units) above the measured number, and the stated range ends above it.
By their numbers in this assay, from the lowest: compounds 4 and 1 (each within the scatter of the next); then compounds 3 and 2 (each within the scatter of the next).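

In this assay, 1-aminobutyl in place of 1-ethylpiperidin-2-yl on a saturated ring carbon gives a 2.0-fold lower number from compound 1 to compound 4 (0.30 log units; within the scatter). Going by these compounds alone, this is the first change at this position, and it shows that the six-membered non-aromatic ring can be given up there, with a smaller open-chain group and a hydrogen-bond donor entering, while the number stays within the scatter. Nothing on hand offers an explanation for this result. The compounds shown leave open how an amino chain longer than 1-aminobutyl, or an ethyl group on the amine of compound 4, would read.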